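Swapping thiophene for trifluoromethylphenyl at the carbonyl

The source may report more compounds than this note shows. Statements on the series, on what has been measured and on what is new or still open speak of the compounds shown alone.

Compound 1 `COc1cc(-c2nnc3n2NC(c2ccco2)C(C(=O)c2ccc(Br)cc2)S3)cc(OC)c1OC`: in a functional assay on MCF7 cells (Homo sapiens) for cytotoxicity, read by MTT assay, with a stated time of 48 h (on this read-out higher numbers stand for weaker inhibition and lower numbers for stronger inhibition), compound 1 gives > 100000 nM, a limit of the assay.
Compound 2 `COc1cc(-c2nnc3n2NC(c2ccco2)C(C(=O)c2cccs2)S3)cc(OC)c1OC`: in this assay compound 2 gives > 100000 nM, also a limit.

Compound 2 thus stands at the assay's limit, not at a number. Among the compounds with values here, the one measured step, a step that the two limits leave unreadable from compound 1 to compound 2, cannot be sized because both values sit at the limit of > 100000 nM in this assay, at which 2 of the 2 values shown sit. Compound 3 `COc1cc(-c2nnc3n2NC(c2ccco2)C(C(=O)c2ccc(C(F)(F)F)cc2)S3)cc(OC)c1OC` differs from compound 2 by 4-(trifluoromethyl)phenyl in place of thiophen-2-yl on a carbonyl carbon. With no readable step to lean on, compound 3 is expected to stay at the limit in this assay, giving an estimated 150000 nM within 50000 nM to 500000 nM. The expected step that the limit leaves unreadable from compound 2 to compound 3 is estimated to fall within the scatter.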

Compound 3, half-maximal inhibitory concentration: 33600 nM
The estimate for compound 3 lay 4.5-fold (0.65 log units) above the measured number; measured number below the stated range.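

The group on the carbonyl carbon can move the number in this assay: 4-(trifluoromethyl)phenyl in place of thiophen-2-yl gives an at least 2.9-fold lower number from compound 2 to compound 3 (0.47 log units; beyond the scatter). A smaller change does this too, as trifluoromethyl in place of bromo on an aromatic carbon gives an at least 2.9-fold lower number from compound 1 to compound 3 (0.47 log units; beyond the scatter). Each step is only a minimum, because its starting value is a limit and not a number: the limit of > 100000 nM in this assay, at which 2 of the 3 values shown sit.

On these data alone, how the number would respond to an amine or a carboxylic acid in place of the trifluoromethyl remains open. So does the true size of either step.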